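This account rests on a few compounds, and the source may have more. Where it says the series, first, only, none or still open, it means among the compounds named here.

Of the compounds shown here, two have been measured in an assay on HEK293 cells for inhibition of acid ceramidase (Homo sapiens), read by fluorescence, with stated times of 10 min and 3 h; on this read-out lower numbers stand for stronger inhibition and higher numbers for weaker inhibition. Compound 2 `O=C(NCCCCc1ccccc1)n1c(=O)oc2cc(C3CCCCC3)ccc21` gives 89 nM, and compound 1 `CN1CCC(c2ccc3c(c2)oc(=O)n3C(=O)NCCCCc2ccccc2)CC1=O` gives 105 nM, the two numbers lying within the scatter of each other. Compound 3 `CN1CCN(c2ccc3c(c2)oc(=O)n3C(=O)NCCCCc2ccccc2)C(=O)C1` carries 4-methyl-2-oxopiperazin-1-yl in place of cyclohexyl on an aromatic carbon. For the measured compounds named here, the only measured step that bears on this, a 1.2-fold lower number from compound 1 to compound 2 (0.07 log units; within the scatter), put cyclohexyl in the place of 1-methyl-2-oxopiperidin-4-yl and changed little; the new change again swaps cyclohexyl for a ring carrying a methyl group and a carbonyl. Compound 3 is therefore expected to show no step beyond the scatter, a 1.3-fold higher number from compound 2 to compound 3 (0.11 log units; within the scatter), with an estimated 115 nM in a range from 55 nM to 240 nM.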

Compound 3, half-maximal inhibitory concentration: 52 nM
Estimate against measurement, compound 3: 2.2-fold (0.34 log units) above, and the stated range ends above it.
By their numbers in this assay, from the lowest: compounds 3, 2 and 1 (each within the scatter of the next, the first and the last beyond it).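

Placing 4-methyl-2-oxopiperazin-1-yl on this aromatic carbon in place of cyclohexyl gives a 1.7-fold lower number from compound 2 to compound 3 (0.23 log units; within the scatter) even though the group brings hetero atoms and hydrogen-bond acceptors that cyclohexyl lacks. For the compounds shown here, replacing 1-methyl-2-oxopiperidin-4-yl with the same group gives a 2.0-fold lower number from compound 1 to compound 3 (0.31 log units; beyond the scatter), the only step so far beyond the scatter, so two six-membered rings that each carry a methyl group and a carbonyl can differ measurably here. Nothing available explains this difference. Still open, going by these compounds, is how a morpholine ring or a carboxylic acid on this carbon would compare, and what the methyl group on the 4-methyl-2-oxopiperazin-1-yl ring contributes.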